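The compounds below may be only part of what the source reports. "The series", "measured", "known", "first", "only" and "open" are said of these compounds alone.

Measured in a functional assay on SW982 cells (Homo sapiens) for inhibition, read by MTT assay, with a stated time of 72 h; a higher number here means a weaker inhibitor, a lower number a stronger inhibitor:
- compound 1 `COc1cc(OC)c(OC)cc1/C=C/C(=O)c1ccccc1`: > 150000 nM, a limit
- compound 2 `COc1cc(OC)c(OC)cc1/C=C/C(=O)c1cc(Cl)ccc1O`: > 150000 nM, a limit

Compound 2 stands only at its limit of > 150000 nM, with no number to start from. Compound 3 `COc1cc(OC)c(OC)cc1/C=C/C(=O)c1cc(O)ccc1O` carries hydroxy in place of chloro on an aromatic carbon, 5-chloro-2-hydroxyphenyl becoming 2,5-dihydroxyphenyl: hydroxy in place of chloro on an aromatic carbon. For the measured compounds named here, the only measured step bearing on this is a step that the two limits leave unreadable from compound 1 to compound 2. That leaves the limit of > 150000 nM in this assay, at which 2 of the 2 values shown sit, as the sole anchor. No measured size carries over, so the expected step of an at least 1.8-fold lower number from compound 2 to compound 3 (0.27 log units; that floor lies within the scatter) in this assay is a loose estimate, towards stronger inhibition. Compound 3 is expected at 80000 nM, with an estimated range of 20000 nM to 150000 nM.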

Compound 3, half-maximal inhibitory concentration: > 150000 nM
Compound 3: no number, only a limit (the forecaster's own chance of this, stated with the estimate: 45%); middle value at least 1.8-fold (0.27 log units) from the limit.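

In this assay, for the compounds shown here, compound 3 gives > 150000 nM, a limit and not a number, so no step among compound 1, compound 2 and compound 3 can be read. How these three compounds truly compare stays open, with one shared limit as the only anchor: the limit of > 150000 nM in this assay, at which 3 of the 3 values shown sit.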